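Compound 3 to compound 4: changing the cyclohexyl group

This account rests on a few compounds, and the source may have more. Where it says the series, first, only, none or still open, it means among the compounds named here.

In a physicochemical assay for solubility, using the shake flask method, in phosphate buffer, measured as kinetic solubility, with a stated time of 20 h, at pH 6.5 (on this read-out lower numbers stand for lower solubility and higher numbers for higher solubility), compound 3 (`FC1(F)CCC(c2nc3cnc(Nc4ccc(C(F)(F)F)cn4)cc3[nH]2)CC1`) gives 99000 nM and compound 2 (`FC(F)(F)c1ccc(Nc2cc3[nH]c(CC4CC4)nc3cn2)nc1`) gives 118000 nM. These two stand level, with a 1.2-fold lower number from compound 2 to compound 3 (0.08 log units; within the scatter). Compound 1 (`FC(F)(F)c1ccc(Nc2cc3[nH]c(C4CC4)nc3cn2)nc1`) gives < 5000 nM, which is a limit of the assay. Compound 3 therefore sits with compound 2, well clear of compound 1, with an at least 19-fold higher number from compound 1 to compound 3 (1.29 log units; beyond the scatter).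

Compound 4 (`FC(F)(F)c1ccc(Nc2cc3[nH]c([C@H]4CC[C@H](C(F)(F)F)CC4)nc3cn2)nc1`) has 4-(trifluoromethyl)cyclohexyl in place of 4,4-difluorocyclohexyl on an aromatic carbon.

For the measured compounds named here, no measured step makes this exact change. The closest guide is the group at the same place in the other compounds: an at least 23-fold higher number from compound 1 to compound 2 (1.37 log units; beyond the scatter) was large, while the change from compound 2 to compound 3 stayed within the scatter. The number can therefore swing widely here, and a moderate fall is expected rather than a collapse, with no change still possible. The expected step is a 2.5-fold lower number from compound 3 to compound 4 (0.39 log units; beyond the scatter). For compound 4 the estimated value is 40000 nM, with an expected range from 8000 nM to 120000 nM.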

Compound 4, solubility: < 5000 nM
Compound 4: only a limit was reported; the forecaster's own chance of this, stated with the estimate: 20%; at least 8.0-fold (0.90 log units) between middle value and limit.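

In this assay compound 4 gives < 5000 nM, a limit of the assay and not a number. The six-membered carbon ring on the aromatic carbon between the two ring nitrogen atoms therefore does not by itself hold the high numbers: 4-(trifluoromethyl)cyclohexyl gives an at least 19-fold lower number from compound 3 to compound 4 (1.29 log units; beyond the scatter), and the change from the smaller cyclopropylmethyl gives an at least 23-fold lower number from compound 2 to compound 4 (1.37 log units; beyond the scatter). The step from compound 1 to compound 4 cannot be read, with both compounds at the same limit: the limit of < 5000 nM in this assay, at which 2 of the 4 values shown sit.

The compounds shown do not separate the trifluoromethyl group from the two defined stereocentres of 4-(trifluoromethyl)cyclohexyl. On these data alone, what an amine or a carboxylic acid in place of the trifluoromethyl group would give in this assay remains open.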